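The compounds below may be only part of what the source reports. "The series", "measured", "known", "first", "only" and "open" are said of these compounds alone.

Working notes on the series. In a functional assay on HCT-116 cells (Homo sapiens) for cytotoxicity, read by MTT assay, with a stated time of 24 h (a lower number here means a stronger inhibitor, a higher number a weaker inhibitor), compound 1 `COc1ccc(/C=C\C(=O)O)c(OCc2cn(-c3ccccc3C#N)nn2)c1CC=C(C)C` gives 38300 nM. Compound 2 `COc1ccc(/C=C\C(=O)O)c(OCc2cn(-c3ccc(NC(C)=O)cc3)nn2)c1CC=C(C)C` gives "not determined" (no result reported) in this assay and contributes no number. Compound 3 `COc1ccc(/C=C\C(=O)O)c(OCc2cn(-c3cccc(C#N)c3)nn2)c1CC=C(C)C` gives 35300 nM in this assay. Among the measured compounds shown here, the only single-point step among the measured compounds is a 1.1-fold lower number from compound 1 to compound 3 (0.04 log units; within the scatter), which moves the nitrile from one position of the phenyl to another. Of the two numbers available, compound 3 holds the lowest, though compound 1 sits within the scatter of it, so the two compounds cannot be separated on these data.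

Compound 4 `COc1ccc(/C=C\C(=O)O)c(OCc2cn(-c3nc4ccccc4s3)nn2)c1CC=C(C)C` differs from compound 3 at one place: 1,3-benzothiazol-2-yl in place of 3-cyanophenyl on an aromatic nitrogen. For the measured compounds named here, no measured step covers this kind of change; the one step known, from the shift of the nitrile within a phenyl, was inside the scatter, and here the whole aryl group on the aromatic nitrogen is exchanged for a bicyclic group. The two measured numbers suggest that the group on this aromatic nitrogen has so far moved this assay little, so no step beyond the scatter is expected, with a wide range to reflect the lack of a matching precedent. The expected step is a 1.0-fold lower number from compound 3 to compound 4 (0.00 log units; within the scatter). Compound 4 is therefore estimated at 35000 nM, in a range from 12000 nM to 100000 nM.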

Compound 4, half-maximal inhibitory concentration: 16400 nM
Beside the measured number, compound 4's estimate is 2.1-fold (0.33 log units) above it, and the stated range covers the measured number.
By their numbers in this assay, from the lowest: compound 4; then compounds 3 and 1 (each within the scatter of the next).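

At the aromatic nitrogen of the five-membered aromatic ring with 3 nitrogen, this assay now shows that the group carried there can move the number beyond the scatter: 1,3-benzothiazol-2-yl in place of the cyanophenyl groups gives a 2.2-fold lower number from compound 3 to compound 4 (0.33 log units; beyond the scatter) and a 2.3-fold lower number from compound 1 to compound 4 (0.37 log units; beyond the scatter), both modest, whereas shifting the nitrile gave only a 1.1-fold lower number from compound 1 to compound 3 (0.04 log units; within the scatter). The exchange removes the nitrile and the single carbon ring and brings in a fused pair of aromatic rings with sulfur and an added ring nitrogen, so several features change in one step and these compounds cannot separate their contributions. No measured information on the compounds bears on the origin of this step.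

Still open, from the compounds shown here alone, is which part of the 1,3-benzothiazol-2-yl group carries the step, a question that 1,3-benzoxazol-2-yl, with oxygen in place of sulfur, or an unsubstituted phenyl would address. Steps involving compound 2 cannot be read, so the effect of an amide on the phenyl remains unknown, as does that of an amine there, and whether the step holds when the carboxylic acid of the shared core is replaced by its methyl ester.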